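Removing one methyl from the chain of compound 2

This account rests on a few compounds, and the source may have more. Where it says the series, first, only, none or still open, it means among the compounds named here.

Compound 1 `COC(=O)NC(CC(=O)N1CCC(n2c(C)nc3cnccc32)CC1)c1ccccc1`: 0.56 mg/kg
Compound 2 `Cc1nc2cnccc2n1CC1CCN(C(=O)CC(C)c2ccccc2)CC1`: 0.033 mg/kg

In a functional assay on the whole organism (arterial blood) with Rattus norvegicus as the target (on this read-out lower numbers stand for an effect already at smaller amounts and higher numbers for an effect only at larger amounts of compound), compound 2 has the lower of the two numbers, and its gap to compound 1 lies beyond the usual scatter. These two compounds differ in more than one place, so that gap cannot be tied to any single group. Compound 3 `Cc1nc2cnccc2n1CC1CCN(C(=O)CCc2ccccc2)CC1` departs from compound 2 by one change: hydrogen in place of methyl on a saturated chain carbon bound to an aromatic carbon and a saturated chain carbon. Among the compounds with values here, no measured pair shows this change alone, so its size remains a judgement. A small move toward a higher number is expected, near the edge of the scatter. The estimated change is a 1.8-fold higher number from compound 2 to compound 3 (0.26 log units; within the scatter). For compound 3 the expected value is 0.06 mg/kg, with an estimated range of 0.015 mg/kg to 0.25 mg/kg.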

Compound 3, dose for 50% inhibition: > 5 mg/kg
Compound 3 ended at the assay's limit (the forecaster's own chance of this, stated with the estimate: 3%); middle value at least 83-fold (1.92 log units) from the limit.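

In this assay, the methyl on the saturated chain carbon bound to an aromatic carbon and a saturated chain carbon proves far from a minor detail: putting hydrogen in its place gives an at least 150-fold higher number from compound 2 to compound 3 (2.18 log units; beyond the scatter). The earlier pair could not show this, since compound 1 and compound 2 differ in more than one place, whereas this step isolates a single small change. Compound 3 stands at a limit of the assay and not at a number, so the step gives only the smallest size the change can have: the limit of > 5 mg/kg in this assay, at which 1 of the 3 values shown sits.

Open, from the compounds shown here alone, is whether only methyl works on this carbon, or whether a larger group such as ethyl, or a hydroxyl or an amine, would keep the low number of compound 2. Also open, going by these compounds, is how the two mirror-image forms of compound 2 would compare.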